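The source may hold more compounds than are shown below. What is called first, only, known or untested is meant among the compounds shown, and "the series" means these compounds.

Compound 2 `O=c1c2ccccc2c(-c2cccnc2)nn1Cc1ccccc1` is the reference for the step in hand. Going by the values given here, in a functional assay (trachea) with Cavia porcellus as the target (a lower number here means a stronger inhibitor, a higher number a weaker inhibitor), compound 2 gives 2450 nM, the lowest of the three numbers so far. Among the compounds with values here, compound 1 `Oc1nnc(-c2cccnc2)c2ccccc12`, which carries nothing at that place, gives 10200 nM in this assay; no step is computed for this pair, and the two values show only that compound 1 sits above compound 2. Compound 3 `COC(=O)c1ccc(Cn2nc(-c3cccnc3)c3ccccc3c2=O)cc1` gives 5890 nM in this assay, reached by a 2.4-fold higher number from compound 2 to compound 3 (0.38 log units; beyond the scatter).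

Compound 4 `CC(C)NC(=O)CCCn1nc(-c2cccnc2)c2ccccc2c1=O` is not yet measured. It differs from compound 2 in one place: 2-(isopropylcarbamoyl)ethyl in place of phenyl on a saturated chain carbon bound to an aromatic nitrogen. Within the data shown here, the only measured step, a 2.4-fold higher number from compound 2 to compound 3 (0.38 log units; beyond the scatter), kept the phenyl and added a methoxycarbonyl, so it bears on this change only loosely; no measured step removes the phenyl or introduces an amide-bearing chain. The values of compound 1 and compound 2 show that the compound lacking any group at that place sits well above compound 2, but that rests on two compounds alone. On this thin footing the step to compound 4 is expected to run upward, with a wide range; the expected step is a 2.0-fold higher number from compound 2 to compound 4 (0.31 log units; beyond the scatter). Compound 4 is estimated at 5000 nM, between 1500 nM and 16000 nM.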

Compound 4, half-maximal inhibitory concentration: 64600 nM
For compound 4 the middle estimate is 13-fold (1.11 log units) below the measured one; measured number above the stated range.
By their numbers in this assay, from the lowest: compound 2; then compounds 3 and 1 (each within the scatter of the next); then compound 4.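

In this assay the result shows that this place, a saturated chain carbon bound to an aromatic nitrogen, is far from indifferent to what it carries: the change from phenyl to 2-(isopropylcarbamoyl)ethyl gives a 26-fold higher number from compound 2 to compound 4 (1.42 log units; beyond the scatter) and is larger than the change on the retained phenyl, a 2.4-fold higher number from compound 2 to compound 3 (0.38 log units; beyond the scatter). Compound 4 at 64600 nM also stands above compound 1 at 10200 nM, so a group here can leave the number on either side of the compound carrying nothing at that place, with compound 2 below compound 1 and compound 4 above it. Nothing measured in the series accounts for this rise, and no supporting data bear on it.

The change removes a ring and brings in an amide in a single step, so the compounds shown leave open whether the rise follows the loss of phenyl, the arrival of the amide, or both together. A plain alkyl chain without the amide, or a phenyl carrying the isopropylcarbamoyl group, would separate these two parts of the change.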